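A few compounds are considered here, and "the series" means these few. Any claim that something is new, unique, unknown or untested is made for them only; others in the source may bear on it.

Working notes on the series. In a functional assay on the whole organism (strain Wistar) for inhibition, with Rattus norvegicus as the target, read by paw edema, with a stated time of 3 h, at a dose of 10 mg/kg by the oral route (a lower number here means less inhibition, a higher number more inhibition at the dose given (going by the name of the read-out)), compound 1 `Clc1ccc(-c2nnc(COc3ccc(-c4ccccc4)cc3)o2)cc1` gives 75% and stands second highest of the three numbers: compound 3 `CC(C)Cc1ccc(C(C)c2nnc(COc3ccc(-c4ccccc4)cc3)o2)cc1` gives 77.3%, a number within the scatter of compound 1, while compound 2 `Clc1ccc(COc2nnc(COc3ccc(-c4ccccc4)cc3)o2)c(Cl)c1` gives 29.5%, well beyond the scatter below compound 1. Within the data shown here, no step between two measured compounds that differ in one place is available, so the pair of compound 1 and compound 2 can only be noted for what the two values show.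

Compound 4 `CCCCNc1nnc(COc2ccc(-c3ccccc3)cc2)o1` has not been measured. It differs from compound 1 in one place: butylamino in place of 4-chlorophenyl on an aromatic carbon. Given that compound 2 29.5% falls far short of compound 1 once the group on that carbon is changed, a drop beyond the scatter is expected, a number 30 percentage points lower from compound 1 to compound 4 (beyond the scatter). Compound 4 is estimated at 45%, in a range from 20% to 68%.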

Compound 4, a percentage reported as inhibition, in the whole organism at one dose (the size of the read-out at that dose, not a potency): 15.9%
Beside the measured number, compound 4's estimate is 29.1 percentage points above it; measured number below the stated range.
By their numbers in this assay, from the lowest: compound 4; then compound 2; then compounds 1 and 3 (each within the scatter of the next).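

Butylamino in place of 4-chlorophenyl on this aromatic carbon gives in this assay a number 59.1 percentage points lower from compound 1 to compound 4 (beyond the scatter) and is the first step at this position read between two measured compounds. The change removes an aromatic ring and adds a hydrogen-bond donor and acceptor together, so this step alone cannot separate those differences. Nothing measured here accounts for the loss.

The compounds shown leave open whether phenylamino, which keeps a ring alongside the nitrogen, would stay close to compound 1. A plain butyl chain, without the nitrogen, is equally unresolved at this position.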